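This account rests on a few compounds, and the source may have more. Where it says the series, first, only, none or still open, it means among the compounds named here.

Measured compounds:
compound 1, `O=c1cc(Oc2ccccc2)c2ccc(OCc3cccc(Cl)c3)cc2o1`: 0%
compound 2, `CCOC(=O)Nc1cc(=O)oc2cc(OCc3cccc(Cl)c3)ccc12`: 21%

Both were tested in an assay on isolated protein (strain Sprague-Dawley) for inhibition of Amine oxidase [flavin-containing] A (Rattus norvegicus), read by spectrophotometry, with a stated time of 5 min, tested at 10 uM; a higher number here means more inhibition at the concentration tested (going by the name of the read-out), a lower number less inhibition. There compound 1 gives 0% and compound 2 gives 21%. Compound 2 thus stands highest of the two numbers shown, and the single measured step, a number 21 percentage points higher from compound 1 to compound 2 (beyond the scatter), separates it from compound 1. Compound 3, `CCNC(=O)Nc1cc(=O)oc2cc(OCc3cccc(Cl)c3)ccc12`, has not yet been measured. It differs from compound 2 in one place: ethylamino in place of ethoxy on a carbonyl carbon. Among the measured compounds shown here, the one measured step concerns a different place on the shared core, so no measured step bears directly on this change, and the data give no ground to expect a move beyond the scatter in this assay in either direction. Compound 3 is therefore estimated to give about 20% in this assay, within a range from 5% to 40%. The expected step is a number 1 percentage points lower from compound 2 to compound 3 (within the scatter), in effect no change.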

Compound 3, a percentage reported as inhibition, at one concentration (the size of the read-out at that concentration, not a potency): 0%
The estimate for compound 3 lay 20 percentage points above the measured number, and the stated range ends above it.
By their numbers in this assay, from the lowest: compounds 1 and 3 (each within the scatter of the next); then compound 2.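

In this assay, the carbonyl carbon on the amide-type nitrogen proves sensitive to a single exchange: ethylamino in place of ethoxy gives a number 21 percentage points lower from compound 2 to compound 3 (beyond the scatter) and so does not keep the inhibition seen with the (ethoxycarbonyl)amino group. Against the phenoxy group on the aromatic carbon, the (ethylcarbamoyl)amino group gives no change at the digits printed from compound 1 to compound 3 (within the scatter) in the same assay, so among the three groups at that carbon only (ethoxycarbonyl)amino stands apart. No measured evidence on the cause of this step is available.

On these data alone, it remains open whether a longer chain on the oxygen, such as butoxy, or a benzyloxy group on this carbonyl carbon would keep or raise the number seen with ethoxy. As far as these compounds go, it is equally open whether dimethylamino would match ethylamino here.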